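The source may hold more compounds than are shown below. What is called first, only, known or untested is meant among the compounds shown, and "the series" means these compounds.

Measured so far in a functional assay on HL-60 cells (Homo sapiens) for inhibition, read by CCK-8 assay, with a stated time of 48 h; on this read-out lower numbers stand for stronger inhibition and higher numbers for weaker inhibition:
compound 1 `Cc1cc(C)cc(NC(=O)NCCNS(=O)(=O)c2ccc(-c3ccccc3OCc3ccccc3)s2)c1` – 2200 nM
compound 2 `COc1ccc(Oc2ccccc2-c2ccsc2S(=O)(=O)N2CCN(C(=S)Nc3ccc([N+](=O)[O-])cc3)CC2)cc1OC` – > 50000 nM
compound 3 `O=C(NCCNS(=O)(=O)c1ccc(-c2ccccc2OCc2ccccc2)s1)Nc1cc(C(F)(F)F)cc(C(F)(F)F)c1` – 11400 nM

Compound 3 stands at the highest of the two numbers shown in this assay; the nearest number belongs to compound 1, which lies lower by a gap beyond the usual scatter. Within the data shown here, compound 2 is the one compound whose result is a limit of this assay, not a number, the limit being (the limit of > 50000 nM in this assay, at which 1 of the 3 values shown sits).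

The step taken from compound 3 leads to compound 4 `O=C(NCCNS(=O)(=O)c1ccc(-c2ccccc2Oc2ccc(O)c(O)c2)s1)Nc1cc(C(F)(F)F)cc(C(F)(F)F)c1`, which has not yet been measured in this assay. The change is 3,4-dihydroxyphenyl in place of benzyl on an oxygen on an aromatic ring. Among the measured compounds shown here, nothing measured among the three compounds isolates this change, so no measured step tells what it does to the read-out. With no guidance in either direction, the expected size of the step from compound 3 to compound 4 in this assay is a 1.1-fold higher number from compound 3 to compound 4 (0.02 log units; within the scatter), that is, nothing beyond the scatter. The number estimated for compound 4 in this assay is 12000 nM, with a range from 3000 nM to 50000 nM.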

Compound 4, half-maximal inhibitory concentration: 10500 nM
Beside the measured number, compound 4's estimate is 1.1-fold (0.06 log units) above it, within the range that was stated.
By their numbers in this assay, from the lowest: compound 1; then compounds 4 and 3 (each within the scatter of the next). At a limit, above all of these: compound 2.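

In this assay, putting 3,4-dihydroxyphenyl in place of benzyl on an oxygen on an aromatic ring gives a 1.1-fold lower number from compound 3 to compound 4 (0.04 log units; within the scatter), the only step shown at this position. The entering group brings two hydrogen-bond donors and two hydrogen-bond acceptors that benzyl lacks, and the read-out still does not separate the two compounds, so in the setting of compound 3 this exchange leaves the number inside the scatter. None of the data shown explains why the read-out does not separate them.

Going by these compounds, what stays open is whether the same exchange would leave the number in place with the rest of compound 1, which has a different group on the urea. Also open, on these data alone, is whether an aminophenyl or a carboxyphenyl group on that oxygen would move the number beyond the scatter.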